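Fluorine on the triazole phenyl of the sulfonamide series

The compounds below may be only part of what the source reports. "The series", "measured", "known", "first", "only" and "open" are said of these compounds alone.

Compound 3 `O=c1[nH]cc(S(=O)(=O)Nc2cccc(-c3cn(-c4ccccc4)nn3)c2)c(=O)[nH]1` gives 11200 nM in a functional assay on HepG2 cells (Homo sapiens) for antiproliferative activity, read by MTT assay, with a stated time of 24 h (a lower number here means a stronger inhibitor, a higher number a weaker inhibitor), the higher of the two numbers shown; compound 1 `Cc1ccc(-n2cc(-c3ccccc3NS(=O)(=O)c3c[nH]c(=O)[nH]c3=O)nn2)cc1` gives 8350 nM, within the scatter of compound 3. Compound 2 `O=c1[nH]cc(S(=O)(=O)Nc2ccccc2-c2cn(-c3cccc(F)c3)nn2)c(=O)[nH]1` returns only a limit of the assay, > 20000 nM in this assay. Compound 4 `O=c1[nH]cc(S(=O)(=O)Nc2cccc(-c3cn(-c4cccc(F)c4)nn3)c2)c(=O)[nH]1` is not yet measured; it differs from compound 3 by fluoro in place of hydrogen on an aromatic carbon. Among the compounds with values here, the only measured step touching a fluorophenyl is the one from compound 1 to compound 2, which brought an at least 2.3-fold higher number from compound 1 to compound 2 (0.37 log units; beyond the scatter), and there the fluorophenyl analogue sits at the limit of > 20000 nM in this assay, at which 1 of the 3 values shown sits; that step exchanges one substituent for another rather than adding fluoro to an unsubstituted phenyl, and it sits on the other positional isomer of the core, so it carries the change to compound 4 only loosely. On that basis a small shift toward a higher number in this assay is expected, of a size that may not clear the scatter. The step from compound 3 to compound 4 is therefore expected to be a 1.3-fold higher number from compound 3 to compound 4 (0.13 log units; within the scatter). Compound 4 is estimated at 15000 nM, expected between 7000 nM and 30000 nM in this assay.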

Compound 4, half-maximal inhibitory concentration: > 20000 nM
Compound 4 ended at the assay's limit; the forecaster's own chance of this, stated with the estimate: 35%; at least 1.3-fold (0.12 log units) between middle value and limit.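

With only hydrogen exchanged for fluoro, phenyl to 3-fluorophenyl is now seen as a single change on the core of compound 3, whereas the earlier step exchanged 4-methylphenyl for 3-fluorophenyl on the other positional isomer of the core. In this assay, this change gives an at least 1.7-fold higher number from compound 3 to compound 4 (0.25 log units; that floor lies within the scatter), a floor set by a limit of the assay, so the direction is suggested but the step is not shown to clear the scatter. Both 3-fluorophenyl compounds, compound 2 and compound 4, now read as limits, one on each positional isomer: the limit of > 20000 nM in this assay, at which 2 of the 4 values shown sit.

As far as these compounds go, the true size of the step remains open, as does whether it lies beyond the scatter. Also open, from the compounds shown here alone, is how an amine or a carboxylic acid on the same aromatic carbon would read in this assay.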